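The source may hold more compounds than are shown below. What is called first, only, known or untested is meant among the compounds shown, and "the series" means these compounds.

Working notes on the series. Three compounds of the shared core have been run in an ADME assay on Huh-7 cells (Homo sapiens) for cytotoxicity; a lower number here means a stronger inhibitor of growth, a higher number a weaker inhibitor of growth. Compound 1 `COc1cc2c(=O)c(C(=O)c3ccc(C)cc3)cn(CCCc3ccccc3)c2cc1OC` is reported as "not active" (no number reported) in this assay, with no number attached. Compound 3 `COc1cc2c(=O)c(C(=O)OCc3cccc(C)c3)cn(Cc3ccc(C(F)(F)F)cc3F)c2cc1OC` gives 7300 nM in this assay. Compound 2 `COc1cc2c(=O)c(C(=O)c3ccc(C)cc3)cn(Cc3ccc(S(N)(=O)=O)cc3)c2cc1OC` is reported in this assay only as a limit, > 25000 nM, and where it stands is known only as the limit of > 25000 nM in this assay, at which 1 of the 3 values shown sits, so no number can be placed on it. Going by the values given here, no pair of measured compounds differs in a single place, so no measured step exists and the size of any single change on this core is unknown from these data.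

Compound 4 `COc1cc2c(=O)c(C(=O)c3ccc(C)cc3)cn(Cc3ccc(Cl)cc3)c2cc1OC` is the next compound to be run. It differs from compound 2 by chloro in place of sulfamoyl on an aromatic carbon. Among the compounds with values here, with no measured step to lean on, no step beyond the usual scatter is expected from this change in this assay, though the limit on compound 2 leaves the true starting point open. The step from compound 2 to compound 4 is estimated at an at least 1.2-fold lower number from compound 2 to compound 4 (0.09 log units; that floor lies within the scatter). Compound 4 is thus expected to give about 20000 nM in this assay, within a range of 6000 nM to 60000 nM, with a fair chance that only a limit is reported again.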

Compound 4, concentration for 50% growth inhibition: 15500 nM
Compound 4: the middle estimate sits 1.3-fold (0.11 log units) above what was measured; the measured number falls inside the stated range.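

Going by these compounds alone, the change from 4-sulfamoylbenzyl to 4-chlorobenzyl gives the first step on the shared core in this assay, and it reads as an at least 1.6-fold lower number from compound 2 to compound 4 (0.20 log units; that floor lies within the scatter). With chloro on this aromatic carbon, compound 4 gives a number, 15500 nM, so this position can carry a group that leaves a value to measure further changes against. The step remains only a floor, one that lies within the scatter and says nothing of the true size of the change, because the entry for compound 2 is a limit and not a number: the limit of > 25000 nM in this assay, at which 1 of the 4 values shown sits.

As far as these compounds go, whether a bromo, a methoxy, an amine or a carboxylic acid in the same place would give a number close to that of compound 4 remains open, so one swap does not yet describe this position. From the compounds shown here alone, compound 1 carries no number and compound 3 differs from compound 4 in more than one place, so neither adds a second step, and the effect of the groups elsewhere on the shared core remains unknown.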